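From anilino to (pyridin-2-yl)amino, starting at a limit

A few compounds are considered here, and "the series" means these few. Any claim that something is new, unique, unknown or untested is made for them only; others in the source may bear on it.

Compound 1 `COC(=O)/C=C/C(=O)N[C@@H](C)Cn1ccc(-c2ccc(C#N)c(Cl)c2)n1` gives "not determined" (no result reported)
Compound 2 `C[C@@H](Cn1ccc(-c2ccc(C#N)c(Cl)c2)n1)NC(=O)C1CC(=O)C1` gives "not determined" (no result reported)
Compound 3 `C[C@@H](Cn1ccc(-c2ccc(C#N)c(Cl)c2)n1)Nc1ccccc1` gives > 30000 nM

In a functional assay on CWR22R cells (Homo sapiens) for antiproliferative activity, read by CCK-8 assay, with a stated time of 6 days (on this read-out lower numbers stand for stronger inhibition and higher numbers for weaker inhibition), compound 3 gives > 30000 nM as a limit of the assay and not a number. Among the measured compounds shown here, compounds 1 and 2 have no result for comparison, so no measured step is available as a guide. Compound 4 `C[C@@H](Cn1ccc(-c2ccc(C#N)c(Cl)c2)n1)Nc1ccccn1` carries pyridin-2-yl in place of phenyl on an amine nitrogen, and the full difference reads pyridin-2-yl in place of phenyl on an amine nitrogen in counted terms. For the measured compounds named here, the only guide is the limit of compound 3 at > 30000 nM so weak inhibition is expected to persist. The expected move an at least 1.5-fold lower number from compound 3 to compound 4 (0.17 log units; that floor lies within the scatter) is small and stays within the usual scatter, with any shift leaning towards stronger inhibition. For compound 4 the estimate is 20000 nM with an expected range from 5000 nM to 30000 nM in this assay.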

Compound 4, half-maximal inhibitory concentration: > 30000 nM
Compound 4 was reported as a limit; the forecaster's own chance of this, stated with the estimate: 60%; middle value at least 1.5-fold (0.17 log units) away from the limit.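

No step can be read between compound 3 and compound 4, since each is reported only as a limit: the limit of > 30000 nM in this assay, at which 2 of the 4 values shown sit.

From the compounds shown here alone, whether pyridin-2-yl in place of phenyl on an amine nitrogen changes inhibition at all remains open.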